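A few compounds are considered here, and "the series" means these few. Any claim that something is new, unique, unknown or untested is made for them only; others in the source may bear on it.

Measured in a functional assay on HepG2 cells (Homo sapiens) for antiproliferative activity, read by CCK-8 assay, with a stated time of 48 h; on this read-out higher numbers stand for weaker inhibition and lower numbers for stronger inhibition:
compound 1 `COc1ccc(/C=C\c2cc(OC)c(OC)c(OC)c2)cc1OCc1ccc(CN[C@H](C(=O)O)[C@H](C)O)cc1` gives > 10000 nM, a limit of the assay and not a number.
compound 2 `COc1ccc(/C=C\c2cc(OC)c(OC)c(OC)c2)cc1OCc1ccc(CN2CC[C@@H](O)C2)cc1` gives 6200 nM.
compound 3 `COc1ccc(/C=C\c2cc(OC)c(OC)c(OC)c2)cc1OCc1ccc(CN2CC[C@@H](C(=O)O)C2)cc1` gives 2300 nM.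

Compound 1 stands at the limit of > 10000 nM in this assay, at which 1 of the 3 values shown sits, so only a bound is known for it. From compound 1, an at least 1.6-fold lower number from compound 1 to compound 2 (0.20 log units; that floor lies within the scatter) and an at least 4.3-fold lower number from compound 1 to compound 3 (0.63 log units; beyond the scatter) both lower the number, and a 2.7-fold lower number from compound 2 to compound 3 (0.43 log units; beyond the scatter) is also beyond the scatter. Compound 4 `COc1ccc(/C=C\c2cc(OC)c(OC)c(OC)c2)cc1OCc1ccc(CN[C@H](C(=O)O)[C@@H](C)O)cc1` keeps every atom and bond: the two compounds have the same atoms and bonds and differ only in configuration as drawn: 1 of 3 stereo elements differ; a stereocentre at a saturated chain carbon is drawn S in compound 1 and R in compound 4. Within the data shown here, none of the measured steps changes configuration alone, so they give no direct guide; they show only that the open-chain amino acid of compound 1 sits at the limit while the ring analogues fall below it. The step is expected to be a step that the limit leaves unreadable from compound 1 to compound 4 in this assay, nothing beyond the scatter. Compound 4 is therefore estimated at 12000 nM, range 4000 nM to 40000 nM, most probably reported again as a limit.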

Compound 4, half-maximal inhibitory concentration: > 10000 nM
Compound 4: only a limit was reported; the forecaster's own chance of this, stated with the estimate: 70%; the middle value is on the limit's open side.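

In this assay compound 4 gives > 10000 nM, a limit of the assay and not a number, so changing the configuration at this saturated chain carbon leaves the open-chain amino acid at the limit and the step from compound 1 cannot be read: the limit of > 10000 nM in this assay, at which 2 of the 4 values shown sit. With the 3-carboxypyrrolidin-1-yl group replaced, the change is an at least 4.3-fold higher number from compound 3 to compound 4 (0.63 log units; beyond the scatter). With the 3-hydroxypyrrolidin-1-yl group replaced, only a floor is known, an at least 1.6-fold higher number from compound 2 to compound 4 (0.20 log units; that floor lies within the scatter).

From the compounds shown here alone, whether the two configurations differ in strength remains open. So does whether a 3-aminopyrrolidin-1-yl group would match the 3-carboxypyrrolidin-1-yl group of compound 3.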